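Series notes: naphthalen-1-yl in place of 4-formylphenyl

This account rests on a few compounds, and the source may have more. Where it says the series, first, only, none or still open, it means among the compounds named here.

Compound 1 `O=Cc1ccc(-c2cn3ccnc3c(-c3ccc4ncn(C5CCCCC5)c4c3)n2)cc1` gives 98% in a functional assay on T47D cells (Homo sapiens) for inhibition, read by sulforhodamine B assay, with a stated time of 48 h, tested at 10 uM; a higher number here means more inhibition at the concentration tested (going by the name of the read-out), a lower number less inhibition. Compound 2 `c1ccc2c(-c3cn4ccnc4c(-c4ccc5ncn(C6CCCCC6)c5c4)n3)cccc2c1` gives 41.3% in this assay; the step of a number 56.7 percentage points lower from compound 1 to compound 2 (beyond the scatter) accompanies (naphthalen-1-yl in place of 4-formylphenyl on an aromatic carbon). Compound 3 `O=Cc1ccc(-c2cn3ccnc3c(-c3ccc4ncn(Cc5ccccc5)c4c3)n2)cc1` gives 98% in this assay, so no change at the digits printed from compound 1 to compound 3 (within the scatter), the change being (benzyl in place of cyclohexyl on an aromatic nitrogen). Compound 4 `c1ccc(Cn2cnc3ccc(-c4nc(-c5cccc6ccccc56)cn5ccnc45)cc32)cc1` has not yet been measured in this assay. It differs from compound 3 by naphthalen-1-yl in place of 4-formylphenyl on an aromatic carbon, the same change as from compound 1 to compound 2, at a place described in identical words; the two cores differ only by the change already described between compound 1 and compound 3. Since no change at the digits printed from compound 1 to compound 3 (within the scatter) shows the core change leaving the read-out unaltered, a step of about the size of a number 56.7 percentage points lower from compound 1 to compound 2 (beyond the scatter) is expected, namely a number 56 percentage points lower from compound 3 to compound 4 (beyond the scatter). Compound 4 is therefore estimated at 42%, between 25% and 60%.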

Compound 4, a percentage reported as inhibition, at one concentration (the size of the read-out at that concentration, not a potency) in the T47D assay: 73.8%
Compound 4: the middle estimate sits 31.8 percentage points below what was measured; measured number outside the range, above it.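

In the T47D assay, naphthalen-1-yl in place of 4-formylphenyl gives a lower number on both cores, with compound 3 at 98% and compound 4 at 73.8%, but a number 24.2 percentage points lower from compound 3 to compound 4 (beyond the scatter) does not match the size of the earlier step: the same change on two cores in the T47D assay, a number 56.7 percentage points lower (beyond the scatter) from compound 1 to compound 2 and a number 24.2 percentage points lower (beyond the scatter) from compound 3 to compound 4, 32.5 percentage points apart, beyond the scatter of two such steps

In the T47D assay, benzyl in place of cyclohexyl gives a number 32.5 percentage points higher from compound 2 to compound 4 (beyond the scatter) with naphthalen-1-yl present, which does not repeat the earlier step with 4-formylphenyl present: the same change on two cores in the T47D assay, no change at the digits printed (within the scatter) from compound 1 to compound 3 and a number 32.5 percentage points higher (beyond the scatter) from compound 2 to compound 4, 32.5 percentage points apart, beyond the scatter of two such steps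

Neither change therefore carries from one core to the other at a fixed size among these four compounds, though they do not show the cause of the difference, and in a physicochemical assay for lipophilicity, using the shake flask method, in phosphate buffer, measured as octanol-water partition, with a stated time of 85 min, at pH 7.4 (a higher number here means a more lipophilic compound, a lower number a more polar compound), compound 3 gives 1.88 and compound 4 gives 2, the comparison giving only a number 0.12 log units higher from compound 3 to compound 4 (within the scatter).

From the compounds shown here alone, whether the dependence extends to other groups remains open, for example a carboxylic acid or an amine at the place of 4-formylphenyl. Going by these compounds, a longer chain on the aromatic nitrogen is equally open.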